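Shifting the hydroxyl on one terminal aryl ring

The source may hold more compounds than are shown below. What is called first, only, known or untested is meant among the compounds shown, and "the series" means these compounds.

Compound 1 `Oc1cccc(-c2cc(-c3ccccc3F)cc(-c3cccc(O)c3)n2)c1` in a functional assay on HCT-15 cells (Homo sapiens) for inhibition (a lower number here means a stronger inhibitor, a higher number a weaker inhibitor), gives 5300 nM. Compound 2 `Oc1ccc(-c2cc(-c3ccccc3F)cc(-c3cccc(O)c3)n2)cc1` in this assay gives 5630 nM. The change between them is 4-hydroxyphenyl in place of 3-hydroxyphenyl on an aromatic carbon, and the step is a 1.1-fold higher number from compound 1 to compound 2 (0.03 log units; within the scatter). Compound 3 `Oc1ccc(-c2cc(-c3ccccc3OC(F)(F)F)cc(-c3cccc(O)c3)n2)cc1` in this assay gives 2310 nM; against compound 2 it carries a 2.4-fold lower number from compound 2 to compound 3 (0.39 log units; beyond the scatter) and gives the lowest number of the three. The difference between the cores of compound 1 and compound 3 is not broken down here; their values show compound 3 with the lower number.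

Compound 4 `Oc1ccc(-c2cc(-c3ccccc3OC(F)(F)F)cc(-c3ccc(O)cc3)n2)cc1` is not yet measured. It differs from compound 3 by 4-hydroxyphenyl in place of 3-hydroxyphenyl on an aromatic carbon. This is the same kind of change as from compound 1 to compound 2, though the surroundings differ: there the place was meta to a 2-fluorophenyl group and meta to a 3-hydroxyphenyl group, here it is meta to a 4-hydroxyphenyl group and meta to a large group. A step of a 1.1-fold higher number from compound 3 to compound 4 (0.03 log units; within the scatter) is expected for compound 4 because a 1.1-fold higher number from compound 1 to compound 2 (0.03 log units; within the scatter) stayed within the scatter. Compound 4 is estimated at 2500 nM in this assay, between 1200 nM and 5500 nM.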

Compound 4, half-maximal inhibitory concentration: 7760 nM
Compound 4: the middle estimate sits 3.1-fold (0.49 log units) below what was measured; the whole stated range lies below it.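

Moving the hydroxyl from 3-hydroxyphenyl to 4-hydroxyphenyl on the core of compound 3 gives, in this assay, a 3.4-fold higher number from compound 3 to compound 4 (0.53 log units; beyond the scatter), so this change does not carry over unchanged from one core to the other: the same change on two cores in this assay, a 1.1-fold higher number (0.03 log units; within the scatter) from compound 1 to compound 2 and a 3.4-fold higher number (0.53 log units; beyond the scatter) from compound 3 to compound 4, 3.2-fold (0.50 log units) apart, beyond the scatter of two such steps

A silent step on the core of compound 1 is therefore no safe guide to the same change on the core of compound 3. The comparison rests on a single pair of steps and does not show which difference between the two cores goes with the larger step, the trifluoromethoxy in place of fluoro or the 4-hydroxyphenyl group already present elsewhere on the core.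

The compounds shown leave open how the 2-fluorophenyl analogue of compound 4 would read, which would separate those two differences. Also open, as far as these compounds go, is how a methoxy group or an amine in place of the hydroxyl on the changed ring would read in this assay.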